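Two Chlorophenyl Lactones and a Third Chlorine

The source may hold more compounds than are shown below. What is called first, only, known or untested is meant among the compounds shown, and "the series" means these compounds.

The three measured compounds share a lactone core that carries a benzyl group and a chlorinated benzyl group on neighbouring ring carbons. Compound 1 `O=C1OC[C@H](Cc2ccccc2)[C@H]1Cc1cccc(Cl)c1` gives 36000 nM in a functional assay on HL-60 cells (Homo sapiens) for cytotoxicity, read by WST assay, with a stated time of 48 h; a lower number here means that less compound is needed, a higher number that more compound is needed for the effect. Compound 2 `O=C1OC[C@H](Cc2ccccc2)[C@H]1Cc1ccc(Cl)cc1` gives 36000 nM in this assay; the two cores differ by 3-chlorophenyl in place of 4-chlorophenyl on a saturated chain carbon bound to a saturated ring carbon, and the step of no change at the digits printed from compound 1 to compound 2 (within the scatter) shows the two as level. Compound 3 `O=C1OC[C@H](Cc2ccccc2)[C@H]1Cc1ccc(Cl)cc1Cl` gives 19000 nM in this assay; it arises from compound 2 by chloro in place of hydrogen on an aromatic carbon, and the step of a 1.9-fold lower number from compound 2 to compound 3 (0.28 log units; within the scatter) is the only one of the three that moves at all, though it stays within the scatter.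

Compound 4 `O=C1OC[C@H](Cc2ccccc2)[C@H]1Cc1cc(Cl)cc(Cl)c1` has not yet been measured in this assay. Among the compounds with values here, it arises from compound 1 by chloro in place of hydrogen on an aromatic carbon, the same kind of change as the one from compound 2 to compound 3 but not the same: in compound 3 the new chloro group sits ortho to a large group, while in compound 4 it sits meta to a large group. Since compound 1 and compound 2 stand level, the earlier step is the best guide. The step from compound 1 to compound 4 is expected to be a 1.8-fold lower number from compound 1 to compound 4 (0.26 log units; within the scatter), resting on the measured step of a 1.9-fold lower number from compound 2 to compound 3 (0.28 log units; within the scatter). Compound 4 is therefore estimated at 20000 nM in this assay, with a range from 9000 nM to 45000 nM.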

Compound 4, half-maximal effective concentration: 23000 nM
For compound 4 the middle estimate is 1.2-fold (0.06 log units) below the measured one; the range from low to high includes it.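

In this assay, chloro in place of hydrogen on an aromatic carbon of the core of compound 1 gives a 1.6-fold lower number from compound 1 to compound 4 (0.19 log units; within the scatter), so this step, like the earlier one, does not stand clear of the usual scatter of repeated measurements. Set side by side, the two steps show no difference that can be told apart: the same change on two cores in this assay, a 1.9-fold lower number (0.28 log units; within the scatter) from compound 2 to compound 3 and a 1.6-fold lower number (0.19 log units; within the scatter) from compound 1 to compound 4, 1.2-fold (0.08 log units) apart, within the scatter of two such steps This shows that, across these two cores, the change carries over without any detectable dependence on which chlorophenyl group it starts from, but it does not show that the added chloro group has a real effect on either core, since neither step lies beyond the scatter, and two cases make no rule for the series.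

The compounds shown vary only chloro groups on one of the two aromatic rings, so it remains open whether a methoxy group, an amine or a carboxylic acid in those places would move the number beyond the scatter. Also open, as far as these compounds go, is whether substituents on the unchlorinated phenyl ring, or a longer chain in place of either benzyl linker, would do so.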